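The source may hold more compounds than are shown below. What is called first, only, known or untested is meant among the compounds shown, and "the series" means these compounds.

Measured compounds:
compound 1, `CC(=O)N1N=C(c2ccc([N+](=O)[O-])cc2)O[C@@H]1c1ccc(Cl)c(Cl)c1`, 7.61 nM
compound 2, `CC(=O)N1N=C(c2ccc([N+](=O)[O-])cc2)OC1c1ccc(Cl)c(Cl)c1`, 9.46 nM

Both compounds were tested in an assay on BTI cells for inhibition of Amine oxidase [flavin-containing] B (Homo sapiens), read by fluorescence and Amplex Red, with a stated time of 15 min; on this read-out lower numbers stand for stronger inhibition and higher numbers for weaker inhibition. Compound 2 holds the highest of the two numbers, with compound 1 nearest to it at a 1.2-fold higher number from compound 1 to compound 2 (0.09 log units; within the scatter), so the two compounds cannot be told apart on this read-out. The only difference between them is that (the fact that one of compounds 1 and 2 is drawn with a defined configuration and the other without, at the place where they differ); compound 1 is drawn with a single configuration at the saturated ring carbon, compound 2 without one.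

Compound 3, `CC(=O)N1N=C(c2ccc([N+](=O)[O-])cc2)O[C@H]1c1ccc(Cl)c(Cl)c1`, has not yet been measured. Relative to compound 2 the change is this: the two compounds have the same atoms and bonds; at least one stereo element is drawn with a configuration in one of them and without one in the other: 1 of 1 stereo elements differ; a stereocentre at a saturated ring carbon is drawn without a configuration in compound 2 and S in compound 3. It is the other drawn configuration at the same carbon, so compound 3 is the mirror-image partner of compound 1, with compound 2 standing between them as the form with no configuration drawn.

Among the measured compounds shown here, the one measured step that bears on this, a 1.2-fold higher number from compound 1 to compound 2 (0.09 log units; within the scatter), was small. A form without a drawn configuration sitting so close to compound 1 leaves room for compound 3 to be somewhat weaker, but not far off. Compound 3 is therefore expected to show a 1.4-fold higher number from compound 2 to compound 3 (0.14 log units; within the scatter), with the estimate for compound 3 being 13 nM and a range from 5 nM to 40 nM.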

Compound 3, half-maximal inhibitory concentration: 523 nM
Compound 3: the middle estimate sits 40-fold (1.60 log units) below what was measured, outside the stated range (above it).
By their numbers in this assay, from the lowest: compounds 1 and 2 (each within the scatter of the next); then compound 3.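

In this assay, compounds 1 and 2 could not show whether the configuration at the saturated ring carbon matters, but going from R to S at that carbon gives a 69-fold higher number from compound 1 to compound 3 (1.84 log units; beyond the scatter), and this large weakening can be tied to that one carbon because nothing else changes: the fact that compounds 1 and 3 differ only in the configuration as drawn. The other new step, a 55-fold higher number from compound 2 to compound 3 (1.74 log units; beyond the scatter), is also large, so the form with no configuration drawn reads close to the R form and far from the S form. Among these three compounds, then, the arrangement in space at this one carbon separates strong from much weaker inhibition, with no atom added or removed.

The compounds shown all carry the same groups, so it remains open whether R stays so clearly ahead of S when the nitro group gives way to an amine or a methoxy group, or the acetyl group to a longer chain. They also cannot say why the S form is so much weaker, since they show only the size of the difference and not how it arises.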